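Neopentyl for phenyl on a second core

This account rests on a few compounds, and the source may have more. Where it says the series, first, only, none or still open, it means among the compounds named here.

Compound 1 `O=C([C@H](O)c1ccccc1)N1CC[C@@H]2C[C@@]21C(=O)NCc1cc(Cl)ccc1-n1cnnn1` is the reference for these notes. In a functional assay on a cell-free system (plasma, Homo sapiens), with a stated time of 3 min (on this read-out higher numbers stand for weaker inhibition and lower numbers for stronger inhibition), compound 1 gives 1100 nM. Compound 2 `O=C(NCc1cc(Cl)ccc1-n1cnnn1)[C@@H]1[C@H]2C[C@H]2CN1C(=O)[C@H](O)c1ccccc1` is built from the same atoms as compound 1, joined differently; the difference between the two cores is not broken down here. In this assay compound 2 gives 960 nM, and this value and that of compound 1 lie within the scatter of each other, so nothing separates the two cores on this read-out.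

Compound 3 `CC(C)(C)C[C@@H](O)C(=O)N1C[C@@H]2C[C@@H]2[C@H]1C(=O)NCc1cc(Cl)ccc1-n1cnnn1` carries the change neopentyl in place of phenyl on a saturated chain carbon bound to a carbonyl carbon and an oxygen on a saturated carbon on the core of compound 2. In this assay compound 3 gives 910 nM. The matched step is a 1.1-fold lower number from compound 2 to compound 3 (0.02 log units; within the scatter), so this exchange leaves the number essentially where it was on that core.

Compound 4 `CC(C)(C)C[C@@H](O)C(=O)N1CC[C@@H]2C[C@@]21C(=O)NCc1cc(Cl)ccc1-n1cnnn1` carries the same change, (neopentyl in place of phenyl on a saturated chain carbon bound to a carbonyl carbon and an oxygen on a saturated carbon), on the core of compound 1; the two change descriptions agree word for word, so it is the same change, not merely the same kind. Its value in this assay is still to be measured. Within the data shown here, the step from compound 1 to compound 4 is expected to be a 1.1-fold lower number from compound 1 to compound 4 (0.04 log units; within the scatter), because the single matched pair available gave a 1.1-fold lower number from compound 2 to compound 3 (0.02 log units; within the scatter) and the two cores themselves gave values within the scatter of each other. On this basis compound 4 is estimated at 1000 nM, with the expected range from 600 nM to 1700 nM. Among the measured compounds shown here, only one prior instance of the change supports this, so the range is kept wide.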

Compound 4, half-maximal inhibitory concentration: 620 nM
Compound 4: middle estimate off by 1.6-fold (0.21 log units), on the high side; low and high end bracket the measured number.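

On the core of compound 1, neopentyl in place of phenyl gives a 1.8-fold lower number from compound 1 to compound 4 (0.25 log units; within the scatter), so on this core, as on the core of compound 2, the exchange stays inside the usual scatter of this assay. Set side by side, the two matched steps cannot be told apart: the same change on two cores in this assay, a 1.1-fold lower number (0.02 log units; within the scatter) from compound 2 to compound 3 and a 1.8-fold lower number (0.25 log units; within the scatter) from compound 1 to compound 4, 1.7-fold (0.23 log units) apart, within the scatter of two such steps. The change therefore carries from one core to the other without a detectable difference on this read-out, but two pairs show only that neopentyl and phenyl are not separated on these two cores, and they do not show that the step would stay the same on any further core.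

Every compound shown carries either phenyl or neopentyl on the saturated chain carbon bound to a carbonyl carbon and an oxygen, so it stays open whether another group at that place, such as an amine, a carboxylic acid or a longer chain, would move the number beyond the scatter on either core. With a single read-out shown, it also stays open whether neopentyl and phenyl remain inseparable in any other assay.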